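This account rests on a few compounds, and the source may have more. Where it says the series, first, only, none or still open, it means among the compounds named here.

Measured compounds:
compound 1 `Cc1ccccc1NC1=C/C(=N/NC(N)=S)C(=O)N=C1Nc1ccccc1C`: 1710 nM
compound 2 `Cc1cccc(NC2=C/C(=N/NC(N)=S)C(=O)N=C2Nc2cccc(C)c2)c1`: 2730 nM
compound 3 `Cc1ccccc1NC1=C/C(=N/N=C(\N)SCc2ccccc2)C(=O)N=C1Nc1ccccc1C`: 17100 nM

All three were read in a functional assay on Bel-7402 cells (Homo sapiens) for antiproliferative activity, read by MTT assay, with a stated time of 72 h; a higher number here means a weaker inhibitor, a lower number a stronger inhibitor. Compound 1 and compound 2 are built from the same atoms joined differently; the difference between the two cores is not broken down here. Their values lie within the scatter of one another, so no order is drawn between them. Compound 3 differs from compound 1 by a group of 11 heavy atoms (8 carbon, 2 nitrogen, 1 sulfur; one six-membered aromatic ring of carbon only) in place of a group of 4 heavy atoms (1 carbon, 2 nitrogen, 1 sulfur; no ring), on a double-bonded nitrogen and this change produced a 10-fold higher number from compound 1 to compound 3 (1.00 log units; beyond the scatter).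

Compound 4 `Cc1cccc(NC2=C/C(=N/N=C(\N)SCc3ccccc3)C(=O)N=C2Nc2cccc(C)c2)c1` has not yet been measured. Relative to compound 2 it carries a group of 11 heavy atoms (8 carbon, 2 nitrogen, 1 sulfur; one six-membered aromatic ring of carbon only) in place of a group of 4 heavy atoms (1 carbon, 2 nitrogen, 1 sulfur; no ring), on a double-bonded nitrogen at the same place, so it is the same change as that made from compound 1 to compound 3. Within the data shown here, only one example of this change is available, and it lies beyond the scatter, so a step of similar size is anticipated here. The expected step is a 9.2-fold higher number from compound 2 to compound 4 (0.96 log units; beyond the scatter). This rests on a 10-fold higher number from compound 1 to compound 3 (1.00 log units; beyond the scatter) applied to the value of compound 2. Compound 4 is therefore estimated to give 25000 nM in this assay, with an expected range from 8000 nM to 80000 nM.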

Compound 4, half-maximal inhibitory concentration: 8720 nM
Compound 4: middle estimate off by 2.9-fold (0.46 log units), on the high side; the range from low to high includes it.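

In this assay, placing the group of 11 heavy atoms with its six-membered aromatic ring on the double-bonded nitrogen, where the ringless group of 4 heavy atoms stood, gives a 3.2-fold higher number from compound 2 to compound 4 (0.50 log units; beyond the scatter). The direction of the change is the same on both cores, a weaker inhibitor each time, but its size does not carry over from one core to the other: the same change on two cores in this assay, a 10-fold higher number (1.00 log units; beyond the scatter) from compound 1 to compound 3 and a 3.2-fold higher number (0.50 log units; beyond the scatter) from compound 2 to compound 4, 3.1-fold (0.50 log units) apart, beyond the scatter of two such steps

Two pairs therefore support only the sign of the step on these two cores, and they give no transferable size and no rule for any further core; they also do not show which difference between the cores goes with the smaller step.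

The compounds shown leave open how a short alkyl chain, a longer chain or an amine would behave in place of this group on the double-bonded nitrogen. They also leave open whether a third core would give a step closer to that of one pair or the other.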